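Swapping the Ring Attached to the Thiocarbonyl Carbon

A few compounds are considered here, and "the series" means these few. Any claim that something is new, unique, unknown or untested is made for them only; others in the source may bear on it.

Compound 1 `Cc1cccc(/C(N)=N/NC(=S)N2CCSCC2)n1` and compound 2 `N/C(=N\NC(=S)N1CCSCC1)c1ccccn1` share one core. In a functional assay on A-431 cells (Homo sapiens) for cytotoxicity, read by MTT assay, with a stated time of 72 h, tested at 30 uM (on this read-out higher numbers stand for more inhibition of growth at the one concentration tested and lower numbers for less inhibition of growth), compound 1 gives 64.5%, while compound 2 gives 81.3%, so compound 2 stands highest of the two numbers, the change being a number 16.8 percentage points higher from compound 1 to compound 2 (beyond the scatter). Compound 3 `N/C(=N\NC(=S)N1CCCC1)c1ccccn1` differs from compound 2 only by pyrrolidin-1-yl in place of thiomorpholin-4-yl on a thiocarbonyl carbon. Within the data shown here, the single known step concerns a methyl on an aromatic carbon, a different place, so it offers no guide to this swap; a step of a number 6.3 percentage points lower from compound 2 to compound 3 (within the scatter) is expected, within the scatter. Compound 3 is estimated at 75% in this assay, ranging from 50% to 95%.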

Compound 3, percent growth inhibition at one concentration: 85.2%
The estimate for compound 3 lay 10.2 percentage points below the measured number, within the range that was stated.
By their numbers in this assay, from the lowest: compound 1; then compounds 2 and 3 (each within the scatter of the next).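

In this assay, the swap on the thiocarbonyl carbon gives a number 3.9 percentage points higher from compound 2 to compound 3 (within the scatter), so this position accepts either ring with no change beyond the scatter. In this pair, the ring sulfur of thiomorpholin-4-yl is therefore not required for growth inhibition at the one concentration tested. Nothing available explains this result.

On these data alone, whether morpholin-4-yl, with oxygen in place of that sulfur, or an open-chain dimethylamino group would keep the reading at this carbon remains open. So does how compound 2 and compound 3 compare at other concentrations.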